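The source may report more compounds than this note shows. Statements on the series, on what has been measured and on what is new or still open speak of the compounds shown alone.

Compound 1 `Nc1nc2c(c(-c3ccco3)cn2[C@@H]2O[C@H](CO)[C@@H](O)[C@H]2O)c(=O)[nH]1`, compound 2 `Nc1nc2c(c(-c3ccsc3)cn2[C@@H]2O[C@H](CO)[C@@H](O)[C@H]2O)c(=O)[nH]1` and compound 3 `Nc1nc2c(c(-c3ccccc3)cn2[C@@H]2O[C@H](CO)[C@@H](O)[C@H]2O)c(=O)[nH]1` share one core and differ only in the aromatic group carried on one aromatic carbon. In a functional assay on K562 cells (Homo sapiens), read by MTT assay, with a stated time of 72 h (a lower number here means a stronger inhibitor, a higher number a weaker inhibitor), compound 3 gives > 20000 nM, which is a limit and not a number. Compound 1 gives > 20000 nM, which is also a limit. Among the measured compounds shown here, compound 2 gives 18300 nM, the only true number so far. The picture is therefore dominated by the limit of > 20000 nM in this assay, at which 2 of the 3 values shown sit.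

The next compound, compound 4 `Nc1nc2c(c(-c3cc4ccccc4o3)cn2[C@@H]2O[C@H](CO)[C@@H](O)[C@H]2O)c(=O)[nH]1`, carries 1-benzofuran-2-yl in place of phenyl on that same aromatic carbon: 1-benzofuran-2-yl in place of phenyl on an aromatic carbon. It keeps one six-membered aromatic ring of carbon only and gains one five-membered aromatic ring with 1 hetero atom.

The useful guides are the earlier swaps of one aromatic group for another. These gave an at least 1.0-fold lower number from compound 1 to compound 2 (0.03 log units; that floor lies within the scatter) and an at least 1.0-fold higher number from compound 2 to compound 3 (0.03 log units; that floor lies within the scatter), while the third comparison is a step that the two limits leave unreadable from compound 1 to compound 3. None of them shows a readable step beyond the scatter, so no clear step in either direction is expected in this assay. The estimated step is an at least 1.1-fold lower number from compound 3 to compound 4 (0.04 log units; that floor lies within the scatter). The estimate for compound 4 is 18000 nM, with an expected range of 7000 nM to 30000 nM.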

Compound 4, half-maximal inhibitory concentration: > 20000 nM
Compound 4 was reported as a limit; the forecaster's own chance of this, stated with the estimate: 60%; at least 1.1-fold (0.04 log units) between middle value and limit.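

Carrying two aromatic rings on this carbon, with 1-benzofuran-2-yl in place of phenyl, brings no visible gain in this assay: compound 4 gives > 20000 nM, which is a limit and not a number. Among the compounds shown here, the only step with a readable floor is an at least 1.0-fold higher number from compound 2 to compound 4 (0.03 log units; that floor lies within the scatter), so this larger group cannot be told apart from thiophen-3-yl, while the steps that join two limits cannot be read at all. The earlier compounds carried a single aromatic ring here, and a group of 9 heavy atoms now leaves the picture unchanged, with nearly every value at the same ceiling: the limit of > 20000 nM in this assay, at which 3 of the 4 values shown sit.

The compounds shown leave open how far past that limit compound 1, compound 3 and compound 4 really lie, so any true differences among them stay hidden. They also leave open whether a group of a different kind on this carbon, such as an amine or a carboxylic acid, would give a value clearly apart from compound 2.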